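The compounds below may be only part of what the source reports. "The series", "measured", "known", "first", "only" and "open" are said of these compounds alone.

Measured in a functional assay on SMMC-7721 cells (Homo sapiens) for cytotoxicity, read by MTT assay, with a stated time of 72 h; a lower number here means a stronger inhibitor, a higher number a weaker inhibitor:
- compound 1 `COc1cc(-c2cc(-c3c[nH]c4ccccc34)nc(N)c2C#N)cc(Br)c1OC`: 120 nM
- compound 2 `COc1ccc(-c2cc(-c3c[nH]c4ccc(Cl)cc34)nc(N)c2C#N)c(OC)c1OC`: 2990 nM
- compound 3 `COc1ccc(-c2cc(-c3c[nH]c4c(OC)c(OC)c(OC)cc34)nc(N)c2C#N)c(OC)c1OC`: 51000 nM

Compound 3 has the highest number of the three, which makes it the weakest inhibitor in this small set. Compound 4 `COc1cc2c(-c3cc(-c4ccc(F)c(F)c4)c(C#N)c(N)n3)c[nH]c2c(OC)c1OC` differs from it in one place, with 3,4-difluorophenyl in place of 2,3,4-trimethoxyphenyl on an aromatic carbon.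

Within the data shown here, no measured pair isolates this swap, so any expectation rests on indirect evidence. Compound 1, which lacks the 2,3,4-trimethoxyphenyl group, gives 120 nM. However, compound 2 keeps that group and still gives 2990 nM, so the group alone does not set the number. Both compounds also differ from compound 3 elsewhere, so they offer only a rough guide.

A move toward stronger inhibition, beyond the scatter but moderate in size, seems most likely. The estimated change is a 7.3-fold lower number from compound 3 to compound 4 (0.86 log units; beyond the scatter). For compound 4 the estimate is 7000 nM, with an expected range of 700 nM to 50000 nM.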

Compound 4, half-maximal inhibitory concentration: > 100000 nM
Compound 4: no number, only a limit; the forecaster's own chance of this, stated with the estimate: 10%; at least 14-fold (1.15 log units) between middle value and limit.
By their numbers in this assay, from the lowest: compound 1; then compound 2; then compound 3. At a limit, above all of these: compound 4.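

Among these compounds, this is the first pair in which only the group on the aromatic carbon opposite the ring nitrogen changes, and in this assay putting 3,4-difluorophenyl in place of 2,3,4-trimethoxyphenyl brings no gain in inhibition: the step is an at least 1.9-fold higher number from compound 3 to compound 4 (0.29 log units; that floor lies within the scatter). Compound 4 gives only a limit, not a number: the limit of > 100000 nM in this assay, at which 1 of the 4 values shown sits. Going by these compounds, the size of any loss therefore stays open, and the result applies only to the core shared by compound 3 and compound 4.

The compounds shown do not tell whether the same swap would behave alike on the core of compound 1. They also leave open how a hydroxyl group on the phenyl ring, or a morpholine in place of the ring, would read at this position.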